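The source may report more compounds than this note shows. Statements on the series, on what has been measured and on what is new or still open speak of the compounds shown alone.

In a functional assay on MCF7 cells (Homo sapiens) for cytotoxicity, read by MTT assay, with a stated time of 72 h (a higher number here means a weaker inhibitor, a lower number a stronger inhibitor), compound 1 `Cc1cc(=O)n(-c2ccc(Br)cc2F)nc1C(=O)Nc1ccc(Oc2ncnc3ccsc23)cc1` gives 9360 nM and compound 2 `Cc1cc(=O)n(-c2ccc(Br)cc2F)nc1C(=O)Nc1ccc(Oc2ncnc3sccc23)cc1` gives 15200 nM as its value, which places it level with compound 1 (a 1.6-fold higher number from compound 1 to compound 2 (0.21 log units; within the scatter)). Compound 3 `Cc1cc(=O)n(-c2ccc(F)cc2)nc1C(=O)Nc1ccc(Oc2ncnc3sccc23)cc1` carries 4-fluorophenyl in place of 4-bromo-2-fluorophenyl on an aromatic nitrogen. Within the data shown here, the one measured step concerns a different part of the molecule, so it does not speak directly to this change, and no shift beyond the scatter is expected in this assay on these data. The expected step is accordingly small (a 1.1-fold higher number from compound 2 to compound 3 (0.02 log units; within the scatter)). For compound 3 the estimated value is 16000 nM (expected range 6000 nM to 40000 nM).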

Compound 3, half-maximal inhibitory concentration: 21000 nM
For compound 3 the middle estimate is 1.3-fold (0.12 log units) below the measured one, within the range that was stated.
By their numbers in this assay, from the lowest: compounds 1, 2 and 3 (each within the scatter of the next, the first and the last beyond it).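

Among these compounds, the first step at this position, the aromatic nitrogen, replaces 4-bromo-2-fluorophenyl with 4-fluorophenyl and gives in this assay a 1.4-fold higher number from compound 2 to compound 3 (0.14 log units; within the scatter). This single change thus leaves compound 2 and compound 3 level, so on this pair the bromine-bearing group and the smaller 4-fluorophenyl cannot be told apart. Nothing available here offers an explanation for this result. The compounds shown carry only halogenated phenyl groups at this position. From the compounds shown here alone, what a phenyl bearing an amine or a carboxylic acid would give in this assay remains open.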